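This account rests on a few compounds, and the source may have more. Where it says the series, first, only, none or still open, it means among the compounds named here.

In a functional assay on MCF7 cells (Homo sapiens) for cytotoxicity, read by MTT assay, with a stated time of 2 days, tested at 10 uM (on this read-out higher numbers stand for a weaker effect at the one concentration tested and lower numbers for a stronger effect), compound 1 `CC(=O)c1cc(-c2ccccc2)cc2cc(-c3ccccc3)[nH]c12` gives 96.2%. Compound 2 `CC(=O)c1cc(-c2ccc(F)cc2)cc2cc(-c3ccccc3)[nH]c12` differs from compound 1 by fluoro in place of hydrogen on an aromatic carbon, and in this assay compound 2 gives 73.8%, so that this change gave a number 22.4 percentage points lower from compound 1 to compound 2 (beyond the scatter). Compound 3 `CC(=O)c1cc(/C=C/c2ccccc2)cc2cc(-c3ccccc3)[nH]c12` in this assay gives 86.5%, and a number 9.7 percentage points lower from compound 1 to compound 3 (within the scatter). The cores of compound 1 and compound 3 differ by 2-phenylethenyl in place of phenyl on an aromatic carbon. Compound 4 `CC(=O)c1cc(/C=C/c2ccc(F)cc2)cc2cc(-c3ccccc3)[nH]c12` has not been measured; it differs from compound 3 by fluoro in place of hydrogen on an aromatic carbon, the same change that took compound 1 to compound 2, at a place described in the same words. A step of a number 20.5 percentage points lower from compound 3 to compound 4 (beyond the scatter) is expected, because the same change earlier gave a number 22.4 percentage points lower from compound 1 to compound 2 (beyond the scatter). Compound 4 is therefore expected to give 66%, within 50% to 86%.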

Compound 4, a percentage reported as activity, at one concentration (the size of the read-out at that concentration, not a potency): 46.5%
Compound 4: the middle estimate sits 19.5 percentage points above what was measured; measured number below the stated range.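

In this assay, fluoro in place of hydrogen on an aromatic carbon gave a number 40 percentage points lower from compound 3 to compound 4 (beyond the scatter), while the two wider changes gave a number 27.3 percentage points lower from compound 2 to compound 4 (beyond the scatter) and a number 49.7 percentage points lower from compound 1 to compound 4 (beyond the scatter). The change moved the number in the same direction on both cores, but its size did not carry over: the same change on two cores in this assay, a number 22.4 percentage points lower (beyond the scatter) from compound 1 to compound 2 and a number 40 percentage points lower (beyond the scatter) from compound 3 to compound 4, 17.6 percentage points apart, beyond the scatter of two such steps. This shows that, across these two pairs, the step is not a fixed amount, but it does not show why the sizes differ or what the change would do on a third core.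

Going by these compounds, whether chloro or methoxy in place of the fluoro would act alike remains open. So does the effect of an amine or a carboxylic acid on the outer phenyl ring.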